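Swapping the Ring Nitrogen Substituent in a Potent Inhibitor

The source may report more compounds than this note shows. Statements on the series, on what has been measured and on what is new or still open speak of the compounds shown alone.

Compound 1, `Cn1cc(-c2cc(F)c(NC(=O)c3cn(CC4CCOCC4)cc(-c4ccc(F)cc4)c3=O)cc2F)c2c(N)ncnc21`, gives 0.5 nM in an assay on isolated protein for inhibition of tyrosine-protein kinase receptor UFO (Homo sapiens), read by ELISA; a higher number here means a weaker inhibitor, a lower number a stronger inhibitor.
Compound 2, `CC(C)n1cc(C(=O)Nc2cc(F)c(-c3c[nH]c4ncnc(N)c34)cc2F)c(=O)c(-c2ccc(F)cc2)c1`, reaches the assay limit, < 0.2 nM, in this assay.

Compound 2 thus stands where the assay stops reporting a number, so only a limit is known for it (the limit of < 0.2 nM in this assay, at which 1 of the 2 values shown sits). Compound 3, `Nc1ncnc2[nH]cc(-c3cc(F)c(NC(=O)c4cn(CC5CCOCC5)cc(-c5ccc(F)cc5)c4=O)cc3F)c12`, differs from compound 2 in one place: (oxan-4-yl)methyl in place of isopropyl on an aromatic nitrogen. Within the data shown here, no step between two measured compounds is available, and the two measured values give no direction for this change. The step expected here, an at least 1.5-fold higher number from compound 2 to compound 3 (0.17 log units; that floor lies within the scatter), would stay within the usual scatter. Compound 3 is therefore estimated at 0.3 nM, between 0.1 nM and 1 nM.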

Compound 3, half-maximal inhibitory concentration: 0.4 nM
Beside the measured number, compound 3's estimate is 1.3-fold (0.12 log units) below it, and the stated range covers the measured number.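

Placing the larger (oxan-4-yl)methyl group on this aromatic nitrogen still leaves a strong inhibitor in this assay, with an at least 2.0-fold higher number from compound 2 to compound 3 (0.30 log units; that floor lies within the scatter). Hydrogen in place of methyl on an aromatic nitrogen of the shared core gives a 1.3-fold lower number from compound 1 to compound 3 (0.10 log units; within the scatter), so that swap cannot be told apart from assay noise. The true size of the first step stays unknown, since compound 2 is known only as a limit: the limit of < 0.2 nM in this assay, at which 1 of the 3 values shown sits.

As far as these compounds go, whether an amine, a carboxylic acid or a longer carbon chain on the ring nitrogen would keep this potency remains open.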